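A few compounds are considered here, and "the series" means these few. Any claim that something is new, unique, unknown or untested is made for them only; others in the source may bear on it.

Series notes. Compound 2 `CC(=O)n1cc(NNC(=O)c2ccc[n+]([O-])c2)c2ccccc21` gives in an ADME assay on cells (Peritoneal macrophage cell, Mus musculus, strain C57BL/6) for cytotoxicity, read by LDH release (a higher number here means a weaker inhibitor, a lower number a stronger inhibitor), a value of 17 ug/mL, and compound 1 `CCOC(=O)c1[nH]c2ccccc2c1/C=N\NC(=O)c1ccncc1` gives 16 ug/mL in this assay; the two numbers lie within the scatter of each other, so neither stands apart. Compound 3 `CC(=O)n1cc(NNC(=O)c2ccncc2)c2ccccc21` is not yet measured. Its structure differs from compound 2 in one place: a group of 6 heavy atoms (5 carbon, 1 nitrogen; one six-membered aromatic ring with 1 hetero atom) in place of a group of 7 heavy atoms (5 carbon, 1 nitrogen, 1 oxygen; one six-membered aromatic ring with 1 hetero atom), on a carbonyl carbon. Within the data shown here, no step between measured compounds covers this change. Because compound 1 carries the entering group and gives 16 ug/mL, no step beyond the scatter is expected in this assay. The expected step of a 1.1-fold lower number from compound 2 to compound 3 (0.03 log units; within the scatter) is accordingly small. Compound 3 is estimated at 16 ug/mL in this assay, within 8 ug/mL to 32 ug/mL.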

Compound 3, half-maximal inhibitory concentration: 50 ug/mL
Compound 3: middle estimate off by 3.1-fold (0.49 log units), on the low side, and the stated range ends below it.
By their numbers in this assay, from the lowest: compounds 1 and 2 (each within the scatter of the next); then compound 3.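

On the carbonyl carbon, pyridin-4-yl in place of the oxygen-bearing ring group gives a 2.9-fold higher number from compound 2 to compound 3 (0.47 log units; beyond the scatter) in this assay. This position is therefore not indifferent to the change, and the higher number belongs to the pyridin-4-yl compound. No measurement at hand bears on the step, and no cause can be assigned to it. Whether the oxygen alone accounts for the step stays open. So does the outcome in this assay series for a phenyl ring or a piperidine ring on the same carbonyl carbon.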